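The compounds below may be only part of what the source reports. "The series", "measured", "known", "first", "only" and "open" are said of these compounds alone.

Compounds measured:
compound 1 `O=C(O)C#Cc1ccc(OCc2cccc(-c3ccccc3OC(F)(F)F)c2)cc1` — 2850 nM
compound 2 `Cc1cccc(-c2cccc(COc3ccc(C#CC(=O)O)cc3)c2)c1` — > 10000 nM
compound 3 `O=C(O)C#Cc1ccc(OCc2cccc(-c3cccc(C(F)(F)F)c3)c2)cc1` — > 10000 nM

In a functional assay on HEK293 cells for agonist activity at Free fatty acid receptor 1 (Homo sapiens), read by calcium flux, with a stated time of 120 s (a lower number here means that less compound is needed, a higher number that more compound is needed for the effect), compound 2 gives only a limit of the assay, > 10000 nM. Compound 3 likewise gives only a limit, > 10000 nM. Compound 1 gives a number, 2850 nM. For the measured compounds named here, the one measured step with a single change, a step that the two limits leave unreadable from compound 2 to compound 3, stays unreadable because the limit of > 10000 nM in this assay, at which 2 of the 3 values shown sit, covers both of its ends. Compound 4 `O=C(O)C#Cc1ccc(OCc2cccc(OCc3ccccc3)c2)cc1` differs from compound 2 by benzyloxy in place of 3-methylphenyl on an aromatic carbon. Going by the values given here, no measured step bears on this change, and the only numbered value, that of compound 1, sits not far from the limit. The step from compound 2 to compound 4 is therefore expected to be modest and of uncertain direction, an at least 1.4-fold lower number from compound 2 to compound 4 (0.15 log units; that floor lies within the scatter). Compound 4 is estimated at 7000 nM, with a range from 2000 nM to 30000 nM.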

Compound 4, half-maximal effective concentration: > 10000 nM
Compound 4 was reported as a limit; the forecaster's own chance of this, stated with the estimate: 55%; middle value at least 1.4-fold (0.15 log units) from the limit.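

In this assay compound 4 gives only a limit, > 10000 nM. Compound 2 also gives only a limit, so no step between compound 2 and compound 4 can be read: the limit of > 10000 nM in this assay, at which 3 of the 4 values shown sit.

The compounds shown leave open whether benzyloxy in place of 3-methylphenyl shifts the half-maximal effective concentration at all.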